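From a Dimethoxyphenyl to a Bromophenyl Group in Mice

The source may report more compounds than this note shows. Statements on the series, on what has been measured and on what is new or still open speak of the compounds shown alone.

In a functional assay on the whole organism (strain Kunming) with Mus musculus as the target, with a stated time of 0.5 h (a higher number here means that more compound is needed for the effect, a lower number that less compound is needed), compound 1 `COc1cc(OC)c(OC)cc1/C=C/COC(=O)/C=C/c1ccc(OC)c(OC)c1` gives > 300 mg/kg, which is a limit of the assay and not a number. Compound 2 `COc1cc(OC)c(OC)cc1/C=C/COC(=O)/C=C/c1c(OC)ccc(OC)c1OC` gives > 300 mg/kg, which is also a limit. The data so far therefore show (the limit of > 300 mg/kg in this assay, at which 2 of the 2 values shown sit), and compound 1 offers no exact starting value.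

Compound 3 `COc1cc(OC)c(OC)cc1/C=C/COC(=O)/C=C/c1cccc(Br)c1` has 3-bromophenyl in place of 3,4-dimethoxyphenyl on a double-bonded chain carbon bound to a double-bonded chain carbon. Going by the values given here, no measured pair shows what such a swap does, so any forecast is rough. A moderate fall in the dose needed in this assay is expected, although a second result at the limit is quite possible. The expected change is an at least 1.5-fold lower number from compound 1 to compound 3 (0.17 log units; that floor lies within the scatter). For compound 3 the estimated value is 200 mg/kg, within an expected range of 70 mg/kg to 450 mg/kg.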

Compound 3, dose for half-maximal effect: 215 mg/kg
Compound 3: the middle estimate sits 1.1-fold (0.03 log units) below what was measured; the measured number falls inside the stated range.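

Compound 3 gives the first exact number in this assay among the compounds shown, 215 mg/kg, so 3-bromophenyl on this double-bonded chain carbon brings the series onto a readable part of the scale. The other values are limits of the assay and not numbers: the limit of > 300 mg/kg in this assay, at which 2 of the 3 values shown sit.

The change at this place can therefore be stated only as an at least 1.3-fold lower number from compound 1 to compound 3 (0.14 log units; that floor lies within the scatter), which leaves its true size unfixed.

The compounds shown leave open whether this result comes from the arrival of the bromine or from the departure of the two methoxy groups, and how other groups, such as an amine or a carboxylic acid, would behave at the same place. A single exact value also cannot show how far the dose might fall across this series.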